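Methylating a Phenol on Two Related Cores

A few compounds are considered here, and "the series" means these few. Any claim that something is new, unique, unknown or untested is made for them only; others in the source may bear on it.

Measured so far:
compound 1 `Nc1ccccc1/C=C/c1cccc(O)c1` gives 20 ug/mL in an ADME assay on HEK293 cells (Homo sapiens) for inhibition, read by MTT assay, with a stated time of 2 days; on this read-out higher numbers stand for weaker inhibition and lower numbers for stronger inhibition;
compound 2 `Nc1ccc(/C=C/c2ccc(O)cc2)cc1` gives 0.8 ug/mL in this assay;
compound 3 `COc1cccc(/C=C/c2ccccc2N)c1` gives 0.5 ug/mL in this assay.

Compound 1 and compound 3 differ in one place: methyl in place of hydrogen on an oxygen on an aromatic ring. That single change made a large step, a 40-fold lower number from compound 1 to compound 3 (1.60 log units; beyond the scatter), so on this core the methylated compound gave the far lower number.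

Compound 2 shares its atoms with compound 1, but they are joined differently; the difference between the two cores is not broken down here. Compound 2 gives a number close to that of compound 3, and the two values fall within the scatter of each other, so no order between them can be read. Against compound 1, compound 2 stands far lower, beyond the scatter.

Compound 4 `COc1ccc(/C=C/c2ccc(N)cc2)cc1` has not yet been measured. It differs from compound 2 by methyl in place of hydrogen on an oxygen on an aromatic ring, the same change as from compound 1 to compound 3. The step from compound 2 to compound 4 in this assay is expected to be smaller than the earlier one, a 2.7-fold lower number from compound 2 to compound 4 (0.43 log units; beyond the scatter), because compound 2 already gives 0.8 ug/mL and the earlier step started from the much higher number of compound 1, 20 ug/mL. Whether the change repeats its effect on this second core rests on one example only. Compound 4 is expected to give about 0.3 ug/mL, estimated to lie between 0.05 ug/mL and 1.5 ug/mL.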

Compound 4, half-maximal inhibitory concentration: 0.012 ug/mL
Estimate against measurement, compound 4: 25-fold (1.40 log units) above; the whole stated range lies above it.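

On the second core the change again made a large step in this assay (a 67-fold lower number from compound 2 to compound 4 (1.82 log units; beyond the scatter)), so swapping hydroxy for methoxy lowered the number here just as it did on the first core. Going by these compounds alone, this is only two pairs of compounds on two cores, which cannot show that the change would behave the same way on any further core, and the numbers alone do not say why methyl in place of hydrogen has this effect. Still, within this small set, the change carried over from one core to the other with no step going against it, and the size of the step did not differ measurably between the two cores: the same change on two cores in this assay, a 40-fold lower number (1.60 log units; beyond the scatter) from compound 1 to compound 3 and a 67-fold lower number (1.82 log units; beyond the scatter) from compound 2 to compound 4, 1.7-fold (0.22 log units) apart, within the scatter of two such steps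

The compounds shown leave open whether the effect belongs to methyl alone or would also appear with a longer chain such as ethyl on the same oxygen. They also leave open what would happen if the whole hydroxy group gave way to a different group, such as an amine or a fluorine atom, or if the amine already present on both cores were changed to an amide.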